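The source may hold more compounds than are shown below. What is called first, only, known or untested is meant among the compounds shown, and "the series" means these compounds.

Working notes on the benzamide series with a thiocarbonyl link. Compound 1 `Nc1ccccc1NC(=O)c1ccc(CSC(=S)N2CCN(c3cccnc3)CC2)cc1` in a functional assay on MGC-803 cells (Homo sapiens) for antiproliferative activity, read by CCK-8 assay, with a stated time of 72 h, tested at 8 uM (on this read-out lower numbers stand for a weaker effect and higher numbers for a stronger effect at the one concentration tested), gives 76.9%. Compound 2 `CN(C(=S)SCc1ccc(C(=O)Nc2ccccc2N)cc1)c1cccnc1` gives 82.5% in this assay, the top number of the three, although its gap to compound 1 lies within the scatter. Compound 3 `Nc1ccccc1NC(=O)c1ccc(CSC(=S)N2CCN(c3ccc(F)cc3)CC2)cc1` gives 48.7% in this assay, and the gap from compound 2 to it lies beyond the scatter. Within the data shown here, the single one-place step measured so far, a number 28.2 percentage points lower from compound 1 to compound 3 (beyond the scatter), points the same way: taking out pyridin-3-yl in favour of 4-fluorophenyl lowers the read-out by a modest amount.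

Compound 4 `Nc1ccccc1NC(=O)c1ccc(CSC(=S)N2CCc3cc(Cl)ccc32)cc1` is not yet measured. Relative to compound 2 it carries 5-chloro-2,3-dihydro-1H-indol-1-yl in place of methyl(pyridin-3-yl)amino on a thiocarbonyl carbon. Pyridin-3-yl is lost here as well, which is the part of the change that the step from compound 1 to compound 3 speaks to; nothing measured covers the move from methyl(pyridin-3-yl)amino to 5-chloro-2,3-dihydro-1H-indol-1-yl on the thiocarbonyl carbon, so only the direction is supported. A downward step of the same modest order as a number 28.2 percentage points lower from compound 1 to compound 3 (beyond the scatter) is expected, with wide uncertainty; the expected step is a number 27.5 percentage points lower from compound 2 to compound 4 (beyond the scatter). For compound 4 in this assay the estimate is 55%, with a range from 35% to 75%.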

Compound 4, a percentage reported as inhibition, at one concentration (the size of the read-out at that concentration, not a potency): 82.2%
Compound 4: middle estimate off by 27.2 percentage points, on the low side, and the stated range ends below it.
By their numbers in this assay, from the lowest: compound 3; then compounds 1, 4 and 2 (each within the scatter of the next).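

On the thiocarbonyl carbon, the exchange of methyl(pyridin-3-yl)amino for 5-chloro-2,3-dihydro-1H-indol-1-yl gives, in this assay, a number 0.3 percentage points lower from compound 2 to compound 4 (within the scatter), so at this place the six-membered aromatic ring with a hetero atom can give way to a six-membered aromatic ring of carbon only, within a larger group carrying chlorine, with no step beyond the scatter. Loss of pyridin-3-yl therefore does not carry a lower read-out in every setting: a number 28.2 percentage points lower from compound 1 to compound 3 (beyond the scatter) remains a finding about the exchange for 4-fluorophenyl on an amine nitrogen in a ring and does not extend to the thiocarbonyl carbon. Nothing available bears on why the two exchanges differ in outcome.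

The compounds shown leave open what the chlorine contributes, which the plain 2,3-dihydro-1H-indol-1-yl group on the thiocarbonyl carbon would address, along with a bromine or a methoxy group in its place. Also open, going by these compounds, is whether a saturated ring such as morpholin-4-yl on the same carbon would fit the same picture as the aromatic groups seen so far.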